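Triazole substituent and HeLa cytotoxicity: notes on the series

The source may hold more compounds than are shown below. What is called first, only, known or untested is meant among the compounds shown, and "the series" means these compounds.

- Compound 1 `COc1ccc(C[C@H]2COC(=O)[C@@H]2Cc2ccc(OCc3cn(-c4ccc(F)cc4)nn3)c(OC)c2)cc1OC`: >= 600000 nM (a limit)
- Compound 2 `COc1ccc(C[C@H]2COC(=O)[C@@H]2Cc2ccc(OCc3cn(Cc4ccccc4Cl)nn3)c(OC)c2)cc1OC`: 84500 nM

Within the data shown here, in an ADME assay on HeLa cells (Homo sapiens) for cytotoxicity, read by MTT assay (a higher number here means a weaker inhibitor, a lower number a stronger inhibitor), compound 2 gives 84500 nM, the only actual number so far. Compound 1 reads >= 600000 nM, which is a limit and not a number.

Compound 3 `COc1ccc(C[C@H]2COC(=O)[C@@H]2Cc2ccc(OCc3cn(-c4ccccc4)nn3)c(OC)c2)cc1OC` has not yet been measured. It carries phenyl in place of 2-chlorobenzyl on an aromatic nitrogen.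

Among the measured compounds shown here, one measured step bears on this change: an at least 7.1-fold lower number from compound 1 to compound 2 (0.85 log units; beyond the scatter). There, 2-chlorobenzyl replaced 4-fluorophenyl on the same aromatic nitrogen. Compound 3 reverses that kind of change, with a phenyl group in place of the 4-fluorophenyl of compound 1. The effect of removing that fluorine has not been measured, and a single step is thin support. A move towards compound 1 is still the likeliest outcome, so a higher number is expected in this assay.

The estimated step is a 3.3-fold higher number from compound 2 to compound 3 (0.52 log units; beyond the scatter). For compound 3 the expected value is 280000 nM, with an estimated range of 80000 nM to 600000 nM.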

Compound 3, half-maximal inhibitory concentration: 124000 nM
Compound 3: middle estimate off by 2.3-fold (0.35 log units), on the high side; the measured number falls inside the stated range.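

In this assay, the exchange of 2-chlorobenzyl for phenyl on the aromatic nitrogen is a 1.5-fold higher number from compound 2 to compound 3 (0.17 log units; within the scatter), so a phenyl group and a 2-chlorobenzyl group cannot be told apart here, and the earlier step between 4-fluorophenyl and 2-chlorobenzyl no longer reads as a simple difference between groups attached directly and through a carbon link. Among these compounds, the larger difference now lies with the single fluoro group: hydrogen in place of fluoro on an aromatic carbon gives an at least 4.8-fold lower number from compound 1 to compound 3 (0.68 log units; beyond the scatter), and compound 1 is the one compound that sets the 4-fluorophenyl group apart from the other two substituents. Compound 1 stands at a limit and not at a number, so this step has a bound only and its full size stays unknown: the limit of >= 600000 nM in this assay, at which 1 of the 3 values shown sits.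

Going by these compounds, what remains open is whether the fluoro step carries over to other substituents on this nitrogen, as a 4-fluorobenzyl group set against a plain benzyl group would show. On these data alone, it is also open whether a substituent of a different kind, such as a carboxylic acid or an amine on a short chain, would move the number beyond the scatter around compound 2 and compound 3.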